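The source may hold more compounds than are shown below. What is called first, only, known or untested is meant among the compounds shown, and "the series" means these compounds.

Measured compounds:
- compound 1, `COc1cc(/C=N/NC(=O)COc2cccc3ccccc23)cc(OC)c1OC`, in an ADME assay on HEL cells (Homo sapiens) for cytotoxicity (on this read-out higher numbers stand for lower toxicity in this test and lower numbers for higher toxicity in this test), gives >= 20 ug/mL, a limit of the assay rather than a number.
- compound 2, `Cc1ccc(/C=N/NC(=O)COc2cccc3ccccc23)cc1`, in this assay gives 20 ug/mL.
- compound 3, `C/C(=N\NC(=O)COc1cccc2ccccc12)c1ccc(O)cc1O`, in this assay gives > 100 ug/mL, again a limit rather than a number.

Compound 3 stands at the upper edge of what is shown: its result is a limit (the limit of > 100 ug/mL in this assay, at which 1 of the 3 values shown sits), so its true value is only known to lie beyond that edge. Compound 1 also sits at a limit (the limit of >= 20 ug/mL in this assay, at which 1 of the 3 values shown sits), and compound 2 gives a number close to it; nothing more can be read into the gap between those two.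

Compound 4, `C/C(=N\NC(=O)COc1cccc2ccccc12)c1ccc([N+](=O)[O-])cc1`, has not yet been measured. It differs from compound 3 in one place: 4-nitrophenyl in place of 2,4-dihydroxyphenyl on a carbon with a double bond to nitrogen. Among the measured compounds shown here, with no pair of measured compounds differing in exactly one place, no measured step guides this change directly.

The expectation for compound 4 is therefore a value somewhat lower than the limit of compound 3, though still within the span where compounds 1 and 2 sit; the expected step is an at least 2.0-fold lower number from compound 3 to compound 4 (0.30 log units; that floor lies within the scatter). Compound 4 is estimated at 50 ug/mL, with a range from 15 ug/mL to 100 ug/mL.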

Compound 4, minimum cytotoxic concentration: 100 ug/mL
Compound 4: the middle estimate sits 2.0-fold (0.30 log units) below what was measured, and the stated range covers the measured number.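

In this assay the size of this change cannot be read, because compound 3 sits at a limit of the assay and not at a number: the limit of > 100 ug/mL in this assay, at which 1 of the 4 values shown sits.

Putting 4-nitrophenyl in place of 2,4-dihydroxyphenyl on a carbon with a double bond to nitrogen gives a number no higher from compound 3 to compound 4 (the limit leaves the size open), so the pair fixes a direction that may be no change at all, and no size. Among the compounds shown here, what it does add is a first real number for this position on this core: with a group of 0 hydrogen-bond donors in place of one with 2, compound 4 gives 100 ug/mL.

The two compounds differ in the whole group, so the pair cannot separate what the hydroxy groups contribute from what the nitro group contributes. A plain phenyl or a 4-aminophenyl at the same place, or a carboxylic acid on the ring, would help to tell these apart, and a compound that gives a number rather than a limit on the high side would let a step at this position be sized.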